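The compounds below may be only part of what the source reports. "The series", "measured", "known", "first", "only" and "open" are said of these compounds alone.

Series notes, Bcl-2 displacement

Measured compounds:
compound 1 `CC1(C)CCC(CN2CCN(c3ccc(C(=O)NS(=O)(=O)c4ccc(NCC5CCOCC5)c([N+](=O)[O-])c4)c(Oc4cnc5[nH]ccc5c4)c3)CC2)=C(c2ccc(C(F)(F)F)c(Cl)c2)C1` — 0.8 nM
compound 2 `CC(C)C(=O)N1CCC(CNc2ccc(S(=O)(=O)NC(=O)c3ccc(N4CCN(CC5=C(c6ccc(C(F)(F)F)cc6)CC(C)(C)CC5)CC4)cc3Oc3cnc4[nH]ccc4c3)cc2[N+](=O)[O-])CC1` — 2.4 nM
compound 3 `CC1(C)CCC(CN2CCN(c3ccc(C(=O)NS(=O)(=O)c4ccc(NC5CCOC5)c([N+](=O)[O-])c4)c(Oc4cnc5[nH]ccc5c4)c3)CC2)=C(c2ccc(C(F)(F)F)cc2)C1` — 1.9 nM

All three were run in an assay on isolated protein for displacement of a labelled ligand from Apoptosis regulator Bcl-2 (Homo sapiens), with a stated time of 15 min; a lower number here means a stronger inhibitor, a higher number a weaker inhibitor. Compound 3 stands second highest of the three numbers: its nearest neighbour is compound 2, which sits a little higher but within the scatter, and the furthest is compound 1, whose number lies lower by a margin beyond the scatter. Compound 1 and compound 3 differ in more than one place, so their two values are simply noted side by side.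

Among the compounds with values here, the single step measured in one place is a 1.3-fold lower number from compound 2 to compound 3 (0.10 log units; within the scatter), a change of the substituent on the aromatic nitrogen that left the number essentially where it was.

Compound 4 `CN1CCC(COc2ccc(S(=O)(=O)NC(=O)c3ccc(N4CCN(CC5=C(c6ccc(C(F)(F)F)cc6)CC(C)(C)CC5)CC4)cc3Oc3cnc4[nH]ccc4c3)cc2[N+](=O)[O-])C1` is not yet measured. It differs from compound 3 by (1-methylpyrrolidin-3-yl)methoxy in place of (oxolan-3-yl)amino on an aromatic carbon. Within the data shown here, no measured step swaps the linking atom of this side chain, so the only guidance is indirect: the one measured change at this position, the step from compound 2 to compound 3, stayed within the scatter, which suggests the region tolerates variation. The expected step of a 1.3-fold higher number from compound 3 to compound 4 (0.12 log units; within the scatter) in this assay is therefore small, likely within the scatter, with direction uncertain. Compound 4 is estimated at 2.5 nM, with a range of 0.8 nM to 8 nM.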

Compound 4, half-maximal inhibitory concentration: 0.75 nM
Beside the measured number, compound 4's estimate is 3.3-fold (0.52 log units) above it; the measured number lies below the stated range.
By their numbers in this assay, from the lowest: compounds 4 and 1 (each within the scatter of the next); then compounds 3 and 2 (each within the scatter of the next).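

In this assay, within the data shown here, replacing the (oxolan-3-yl)amino group with (1-methylpyrrolidin-3-yl)methoxy gives a 2.5-fold lower number from compound 3 to compound 4 (0.40 log units; beyond the scatter) and is the first change at this position, on an aromatic carbon ortho to a nitro group, with a step beyond the scatter; the earlier 1.3-fold lower number from compound 2 to compound 3 (0.10 log units; within the scatter) had left open whether this substituent mattered at all. The entering group has 0 hydrogen-bond donors against 1 for the group it replaces, so a donor on this substituent is not required for a low number in this series. The step changes the linking atom, the hetero atom of the five-membered ring and the size of the group together, and nothing available here explains it or assigns it to any one of these.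

Still open, as far as these compounds go, is which part of the change carries the step: a (1-methylpyrrolidin-3-yl)methylamino group would hold the ring and change only the linking atom, while an (oxolan-3-yl)methoxy group would hold the oxygen link and restore the ring oxygen. Also open, from the compounds shown here alone, is how a pyrrolidine with a free ring amine or a longer chain to the same ring would read at this position.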